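Compound 3 to compound 4: changing the nitrogen substituent

This account rests on a few compounds, and the source may have more. Where it says the series, first, only, none or still open, it means among the compounds named here.

Measured in a functional assay on HT-29 cells (Homo sapiens) for inhibition, read by CCK-8 assay, with a stated time of 24 h; on this read-out lower numbers stand for stronger inhibition and higher numbers for weaker inhibition:
- compound 1 `Cc1cccc(-n2cc(-c3ccc(/C=C4\C(=O)Nc5ccccc54)cc3)nn2)c1`: 3940 nM
- compound 2 `O=C1Nc2ccccc2/C1=C/c1ccc(-c2cn(-c3cccc(F)c3)nn2)cc1`: > 20000 nM (a limit)
- compound 3 `O=C1Nc2ccc(F)cc2/C1=C/c1ccc(-c2cn(-c3cccc(F)c3)nn2)cc1`: > 12900 nM (a limit)

Compound 3 gives only a limit, > 12900 nM, and no number. Compound 4 `O=C1Nc2ccc(F)cc2/C1=C/c1ccc(-c2cn(-c3ccc(Cl)c(C(F)(F)F)c3)nn2)cc1` keeps the rest of compound 3 and changes one group on an aromatic nitrogen: 4-chloro-3-(trifluoromethyl)phenyl in place of 3-fluorophenyl on an aromatic nitrogen.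

Within the data shown here, two measured steps bear on this change. The only readable one is an at least 5.0-fold higher number from compound 1 to compound 2 (0.70 log units; beyond the scatter), with fluoro in place of methyl on an aromatic carbon of the same group that changes here. The other is a step that the two limits leave unreadable from compound 2 to compound 3, with fluoro in place of hydrogen on an aromatic carbon, and it gives no size. Neither step covers the entering group, so the support is thin.

Compound 1 at 3940 nM shows that a number can be reached with a different group at this place, so a lower number is expected in this assay. The expected change is an at least 1.8-fold lower number from compound 3 to compound 4 (0.26 log units; that floor lies within the scatter). For compound 4 the estimate is 7000 nM, with an expected range from 2000 nM to 20000 nM.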

Compound 4, half-maximal inhibitory concentration: 16500 nM
Estimate against measurement, compound 4: 2.4-fold (0.37 log units) below; low and high end bracket the measured number.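

Compound 3 gives only a limit, > 12900 nM. Among these compounds, compound 4 gives 16500 nM, and no step from compound 3 to it can be read. Still open, on these data alone, is whether 4-chloro-3-(trifluoromethyl)phenyl in place of 3-fluorophenyl raises or lowers the number on this shared core, and by how much.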